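A few compounds are considered here, and "the series" means these few. Any claim that something is new, unique, unknown or untested is made for them only; others in the source may bear on it.

Compound 2, with the structure `Cc1nc(S(C)(=O)=O)ccc1Oc1ncnc(OC2CCN(C(=O)OC(C)(C)C#N)CC2)c1F`, gives the highest number of the three measured compounds in a functional assay on isolated protein for inhibition of Glucose-dependent insulinotropic receptor (Rattus norvegicus), read by HTRF and cAMP accumulation (on this read-out higher numbers stand for an effect only at larger amounts of compound and lower numbers for an effect already at smaller amounts), namely 1320 nM. Compound 3 `Cc1nc(S(C)(=O)=O)ccc1Oc1ncnc(OC2CCN(C(=O)OC(C)F)CC2)c1F` stands nearest to it, with 315 nM in this assay, and compound 1 `Cc1nc(S(C)(=O)=O)ccc1Oc1ncnc(OC2CCN(C(=O)OC(C)C)CC2)c1F` furthest, with 142 nM in this assay. Compound 4 `Cc1nc(S(C)(=O)=O)ccc1Oc1ncnc(OC2CCN(C(=O)O[C@H](C)CF)CC2)c1F` has not yet been measured. The change from compound 2 to compound 4 is 1-(fluoromethyl)ethyl in place of 1-cyano-1-methylethyl on an oxygen next to a carbonyl group. For the measured compounds named here, two measured steps bear on this. Removing the nitrile gave a lower number: a 4.2-fold lower number from compound 2 to compound 3 (0.62 log units; beyond the scatter). Adding the nitrile onto the unsubstituted chain gave the reverse: a 9.3-fold higher number from compound 1 to compound 2 (0.97 log units; beyond the scatter). Compound 4 carries no nitrile, so the step is expected to move downward, in the direction of compound 3 and compound 1. Because compound 3 reached 315 nM and compound 1 reached 142 nM, compound 4 is estimated to land between them, a step of a 6.0-fold lower number from compound 2 to compound 4 (0.78 log units; beyond the scatter). For compound 4 the expected value in this assay is therefore 220 nM, with a range from 90 nM to 550 nM.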

Compound 4, half-maximal effective concentration: 1520 nM
The estimate for compound 4 lay 6.9-fold (0.84 log units) below the measured number; the measured number lies above the stated range.
By their numbers in this assay, from the lowest: compound 1; then compound 3; then compounds 2 and 4 (each within the scatter of the next).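

In this assay, the nitrile proves unnecessary for a high number: 1-(fluoromethyl)ethyl on an oxygen next to a carbonyl group cannot be told apart from 1-cyano-1-methylethyl (a 1.2-fold higher number from compound 2 to compound 4 (0.06 log units; within the scatter)). Where the fluoro sits on this small chain matters, as 1-(fluoromethyl)ethyl in place of 1-fluoroethyl gives a clear rise (a 4.8-fold higher number from compound 3 to compound 4 (0.68 log units; beyond the scatter)), and fluoro in place of hydrogen two bonds along the chain from that oxygen gives the largest step among these compounds (an 11-fold higher number from compound 1 to compound 4 (1.03 log units; beyond the scatter)). Nothing available explains why this fluoro placement raises the number.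

From the compounds shown here alone, it remains open whether the mirror-image form of compound 4 behaves the same way. Going by these compounds, it is also open whether difluoromethyl or trifluoromethyl in place of fluoromethyl, or a longer chain, would keep the number as high.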